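From ethyl to propyl: compound 2 and compound 3

The source may hold more compounds than are shown below. What is called first, only, known or untested is meant among the compounds shown, and "the series" means these compounds.

Measured so far in a functional assay on MCF7 cells (Homo sapiens) for inhibition, read by MTT assay, with a stated time of 72 h (a lower number here means a stronger inhibitor, a higher number a weaker inhibitor), with the half-maximal inhibitory concentration as read-out:
Compound 1 `Cc1ccc(NC(=O)C2CCN(C/C=C/c3ccccc3)CC2)cc1` gives 30000 nM
Compound 2 `CCc1ccc(NC(=O)C2CCN(C/C=C/c3ccccc3)CC2)cc1` gives 20000 nM

On these numbers compound 2 has a single neighbour, compound 1, and the two lie within the scatter of each other. Compound 3 `CCCc1ccc(NC(=O)C2CCN(C/C=C/c3ccccc3)CC2)cc1` takes compound 2 from 4-ethylphenyl to 4-propylphenyl, with methyl in place of hydrogen on a saturated chain carbon, two bonds along the chain from an aromatic carbon. Among the measured compounds shown here, one measured step bears on this change, the methyl in place of hydrogen on a saturated chain carbon bound to an aromatic carbon, and it is a 1.5-fold lower number from compound 1 to compound 2 (0.18 log units; within the scatter). For the measured compounds named here, with only that step as a guide, no change beyond the scatter is expected in this assay, and the expected step is a 1.1-fold lower number from compound 2 to compound 3 (0.05 log units; within the scatter). Compound 3 is estimated at 18000 nM, with an expected range of 8000 nM to 40000 nM.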

Compound 3, half-maximal inhibitory concentration: 9030 nM
Estimate against measurement, compound 3: 2.0-fold (0.30 log units) above; low and high end bracket the measured number.
By their numbers in this assay, from the lowest: compound 3; then compounds 2 and 1 (each within the scatter of the next).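

In this assay, among the compounds shown here, this added methyl, on a saturated chain carbon, two bonds along the chain from an aromatic carbon, gives the first single-carbon step beyond the scatter: a 2.2-fold lower number from compound 2 to compound 3 (0.35 log units; beyond the scatter), a modest change. Across the full change of chain, the step is a 3.3-fold lower number from compound 1 to compound 3 (0.52 log units; beyond the scatter), also modest, so the 4-propylphenyl group of compound 3 sets it apart from both compound 1 and compound 2. No measurement at hand accounts for either step.

Going by these compounds, whether a longer chain such as butyl would extend this gain remains open, as does the effect of a branched isopropyl group or a terminal amine or carboxylic acid. All three compounds differ only in this chain, so they say nothing about changes elsewhere on the shared core.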